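Methyl on the Aromatic Ring of Compound 2

The source may hold more compounds than are shown below. What is called first, only, known or untested is meant among the compounds shown, and "the series" means these compounds.

Compound 1, `CN1C(=O)C(O)(Cc2nnn[nH]2)c2ccccc21`, gives in a functional assay on PC-3 cells (Homo sapiens) for antiproliferative activity, read by MTT assay, with a stated time of 48 h (a higher number here means a weaker inhibitor, a lower number a stronger inhibitor), a value of 44800 nM.
Compound 2, `CCN1C(=O)C(O)(Cc2nnn[nH]2)c2ccccc21`, reaches only the limit of this assay, > 100000 nM.
Compound 3, `O=C1N(Cc2ccc(Br)cc2)c2ccc(F)cc2C1(O)Cc1nnn[nH]1`, likewise sits at the limit, > 100000 nM.

Compound 2 therefore stands not on a number but on a limit in this assay, and the limit of > 100000 nM in this assay, at which 2 of the 3 values shown sit, shows that compound 3 sits at the same limit. Within the data shown here, the one measured step, an at least 2.2-fold higher number from compound 1 to compound 2 (0.34 log units; beyond the scatter), concerns the group on the amide-type nitrogen and leaves the aromatic ring untouched. Compound 4, `CCN1C(=O)C(O)(Cc2nnn[nH]2)c2cc(C)ccc21`, differs from compound 2 by methyl in place of hydrogen on an aromatic carbon. Among the measured compounds shown here, no measured step touches that ring, so nothing among the measured compounds indicates how large a change, or in which direction, this methyl brings in this assay; the only guide is that compound 2 and compound 3 both sit at the limit. The step from compound 2 to compound 4 is therefore expected to be small, a number no higher from compound 2 to compound 4 (the limit leaves the size open), with the result most likely reported again as a limit. Compound 4 is estimated at 100000 nM, between 30000 nM and 300000 nM, in this assay.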

Compound 4, half-maximal inhibitory concentration: > 100000 nM
Compound 4 was reported as a limit; the forecaster's own chance of this, stated with the estimate: 70%; the middle value sits exactly at the limit.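

Compound 4, like compound 2, is reported in this assay only as a limit, and no step can be read between the two. That limit is shared by most of the series: the limit of > 100000 nM in this assay, at which 3 of the 4 values shown sit.

The compounds shown leave open whether methyl in place of hydrogen on an aromatic carbon changes the result in this assay at all, and in which direction.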